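The compounds below may be only part of what the source reports. "The series", "measured", "known", "first", "only" and "open" are said of these compounds alone.

Measured so far in a functional assay on A549 cells (Homo sapiens) for cytotoxicity, with a stated time of 48 h; a lower number here means a stronger inhibitor, a higher number a weaker inhibitor:
- compound 1 `C[S+]([O-])/C=C/c1cc(=O)c2ccccc2o1`: 1900 nM
- compound 2 `C[S+]([O-])/C=C/c1cc(=O)c2cc(Cl)ccc2o1`: 1700 nM

Not yet measured:
- compound 3 `COc1ccc2oc(/C=C/[S+](C)[O-])cc(=O)c2c1`

Within the data shown here, compound 2 stands within the scatter of compound 1, so the two values give no order, and the series so far occupies a single narrow band of numbers. The next change is methoxy in place of chloro on an aromatic carbon. Among the measured compounds shown here, the only measured step that bears on it is a 1.1-fold lower number from compound 1 to compound 2 (0.05 log units; within the scatter), with chloro in place of hydrogen on an aromatic carbon. That single step shows no response in this assay to the one substitution tested. For the measured compounds named here, no methoxy compound has been measured, so the evidence for this change is thin and a wider range is warranted. No step beyond the scatter is expected, and no direction can be argued from the data. The estimated change is a 1.1-fold higher number from compound 2 to compound 3 (0.02 log units; within the scatter). Compound 3 is expected at 1800 nM, with an estimated range of 900 nM to 3600 nM.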

Compound 3, half-maximal inhibitory concentration: 1600 nM
Estimate against measurement, compound 3: 1.1-fold (0.05 log units) above; the measured number falls inside the stated range.
By their numbers in this assay, from the lowest: compounds 3, 2 and 1 (each within the scatter of the next).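

In this assay, replacing chloro with methoxy on this aromatic carbon gives a step within the scatter (a 1.1-fold lower number from compound 2 to compound 3 (0.03 log units; within the scatter)), so the position now has a second substituent to compare with chloro, and the two cannot be told apart. The comparison with the unsubstituted compound also stays within the scatter (a 1.2-fold lower number from compound 1 to compound 3 (0.07 log units; within the scatter)), which extends the earlier result for chloro to a group with two heavy atoms and one hydrogen-bond acceptor, and hydrogen, chloro and methoxy at this place now share a single narrow band of numbers. No measured information on the series bears on why these three compounds fall so close together.

The compounds shown leave open whether any group at this aromatic carbon moves the number beyond the scatter, for example an amine, a carboxylic acid or a longer alkoxy chain such as butoxy. They also leave open how the other aromatic carbons of the core respond, and how much the number depends on the side chain that all three compounds share.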